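A Sulfanyl Group Added to the Ethyl Chain

This account rests on a few compounds, and the source may have more. Where it says the series, first, only, none or still open, it means among the compounds named here.

Measured so far:
compound 1, `C[Si](C)(C)c1ccc2nc(N)sc2c1`, 5 mg/kg
compound 2, `CCn1c(=N)sc2cc(OC(F)(F)F)ccc21`, 5 mg/kg

Both compounds were tested in a functional assay on the whole organism with Rattus norvegicus as the target; on this read-out higher numbers stand for an effect only at larger amounts of compound and lower numbers for an effect already at smaller amounts. In this assay compound 1 gives 5 mg/kg. In this assay compound 2 gives 5 mg/kg, which is level with the value of compound 1 at the digits shown, so the two values lie within the usual scatter of each other and no order can be drawn between them.

Compound 3, `N=c1sc2cc(OC(F)(F)F)ccc2n1CCS`, has not yet been measured in this assay. It is built from compound 2 by one change: sulfanyl in place of hydrogen on a saturated chain carbon, two bonds along the chain from an aromatic nitrogen. Among the measured compounds shown here, no pair of measured compounds shows the effect of this particular change, so there is nothing in the present numbers to say which way it will move the read-out, or whether it will move it at all.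

For the measured compounds named here, with no step to lean on, the expectation for compound 3 is a value close to that of compound 2, with the step of a 1.2-fold higher number from compound 2 to compound 3 (0.08 log units; within the scatter) expected to stay within the scatter. Compound 3 is accordingly estimated at 6 mg/kg, with a range from 2 mg/kg to 18 mg/kg.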

Compound 3, dose for half-maximal effect: 2 mg/kg
For compound 3 the middle estimate is 3.0-fold (0.48 log units) above the measured one; the measured number falls inside the stated range.
By their numbers in this assay, from the lowest: compound 3; then compounds 1 and 2 (each within the scatter of the next).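

The ethyl chain of compound 2 is not a silent part of the molecule. In this assay the exchange of hydrogen for sulfanyl, on a saturated chain carbon, two bonds along the chain from an aromatic nitrogen, gives a 2.5-fold lower number from compound 2 to compound 3 (0.40 log units; beyond the scatter) and so turns ethyl into 2-sulfanylethyl with a modest gain that lies beyond the scatter. The earlier compounds offered no step at this position, and no measurement at hand bears on why the number moved here.

One step cannot tell whether sulfanyl itself matters or whether other groups at the end of this chain would do the same. Going by these compounds, a hydroxyl, an amine, a carboxylic acid or a longer chain carrying sulfanyl further out would each test this, and whether the same change repeats on a different core also stays open.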